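The source may report more compounds than this note shows. Statements on the series, on what has been measured and on what is new or still open speak of the compounds shown alone.

Measured in a functional assay on MCF7 cells (Homo sapiens) for antiproliferative activity, read by MTT assay, with a stated time of 72 h; on this read-out higher numbers stand for weaker inhibition and lower numbers for stronger inhibition:

- Compound 1 `O=C(N/N=C/c1cccc(Cl)c1Cl)Nc1ccc(Oc2ccnc3[nH]ccc23)c(F)c1`: "not active" (no number reported)
- Compound 2 `O=C(N/N=C/c1ccc(O)cc1)Nc1ccc(Oc2ccnc3[nH]ccc23)c(F)c1`: "not active" (no number reported)
- Compound 3 `O=C(N/N=C/c1ccc(O)cc1O)Nc1ccc(Oc2ccnc3[nH]ccc23)c(F)c1`: 48000 nM

Compound 1 has no single number to stand on. It was reported only as "not active" (no number reported), and compound 2 likewise has only the entry "not active" (no number reported). Of the three measured compounds, only compound 3 has a number, 48000 nM, so compound 1 cannot be placed on a numerical scale against either of the others.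

The next compound to be measured is compound 4 `O=C(N/N=C/c1cccc(Cl)c1Cl)Nc1ccc(Oc2ccnc3[nH]ccc23)cc1`. The structural change is hydrogen in place of fluoro on an aromatic carbon, ortho to a large group and meta to a large group. The rest of the structure of compound 1 is unchanged.

The measured compounds include no single swap of this kind, so the data offer no direct guide to its effect. In this assay, a small step is expected, with no direction favoured and nothing beyond the usual scatter. Compound 4 may well be reported without a number, as compound 1 was. If it does give a number, that number is expected to lie in the weak range shown by compound 3 at 48000 nM.

For compound 4, the estimated value is 35000 nM, with an expected range from 10000 nM to 100000 nM.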

Compound 4, half-maximal inhibitory concentration: "not active" (no number reported)
The entry for compound 4 holds no number; the estimate stays without a comparison.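

Compound 1 and compound 4 both stand in this assay as "not active" with no number, so no step can be read between them. Nothing shown offers an explanation for this result. The compounds shown leave open whether hydrogen in place of fluoro changes antiproliferative potency at all.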